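The compounds below may be only part of what the source reports. "The series", "measured", "known", "first", "only" and "open" are said of these compounds alone.

Compound 1 `OCC(CO)OCn1c(Cl)nc2cc(Cl)c(Cl)cc21` is assessed in a functional assay on KB cells (Homo sapiens) for inhibition; a lower number here means a stronger inhibitor, a higher number a weaker inhibitor. In this assay compound 1 gives only a limit, > 100000 nM. Compound 2 `OCC(CO)OCn1c(SCc2ccccc2)nc2c(Cl)c(Cl)ccc21` gives 60000 nM in this assay. Compound 3 `OCC(CO)OCn1cnc2c(Cl)c(Cl)ccc21` gives only a limit in this assay, > 100000 nM. The step of an at least 1.6-fold higher number from compound 2 to compound 3 (0.22 log units; that floor lies within the scatter) is the only step among these three compounds, and because of the limit of > 100000 nM in this assay, at which 2 of the 3 values shown sit, its true size cannot be read beyond its floor. Compound 4 `OCC(CO)OCn1c(S)nc2cc(Cl)c(Cl)cc21` differs from compound 1 by sulfanyl in place of chloro on an aromatic carbon. Going by the values given here, no measured step concerns this exchange. The expectation therefore rests on compound 1 alone, whose value is a limit, > 100000 nM. Compound 4 is thus expected to give about 100000 nM, between 30000 nM and 300000 nM, an estimated step of a number no higher from compound 1 to compound 4 (the limit leaves the size open) that stays within the scatter.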

Compound 4, half-maximal inhibitory concentration: > 100000 nM
Compound 4: only a limit was reported; the forecaster's own chance of this, stated with the estimate: 60%; the middle value lies on the limit itself.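

Compound 1 and compound 4 each give only a limit in this assay, so no step between them can be read: the limit of > 100000 nM in this assay, at which 3 of the 4 values shown sit.

On these data alone, how strongly either compound inhibits, and whether sulfanyl in place of chloro changes that, stays open.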